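This account rests on a few compounds, and the source may have more. Where it says the series, first, only, none or still open, it means among the compounds named here.

Measured in a functional assay on MT4 cells (Homo sapiens) for cytotoxicity; a lower number here means a stronger inhibitor, a higher number a weaker inhibitor:
- Compound 1 `COc1cccc(Sc2cccc(N)c2C#N)c1`: > 200000 nM, which is a limit of the assay and not a number.
- Compound 2 `N#Cc1c(N)cccc1Sc1cccc(Cl)c1`: 53000 nM
- Compound 3 `N#Cc1cccc(Sc2cccc(N)c2C#N)c1`: 80000 nM

Only compound 2 and compound 3 have actual numbers in this assay, and they lie within the scatter of each other: a 1.5-fold higher number from compound 2 to compound 3 (0.18 log units; within the scatter). Compound 4 `N#Cc1c(N)cccc1Sc1cc(Cl)cc(Cl)c1` keeps the structure of compound 2 but carries chloro in place of hydrogen on an aromatic carbon, meta to a chloro group: chloro in place of hydrogen on an aromatic carbon.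

Among the measured compounds shown here, no measured step adds a group in place of hydrogen, so the evidence is indirect. Chloro in place of methoxy gave an at least 3.7-fold lower number from compound 1 to compound 2 (0.57 log units; beyond the scatter), and cyano in place of methoxy gave an at least 2.5-fold lower number from compound 1 to compound 3 (0.39 log units; beyond the scatter). Going by these compounds, both steps rest on (the limit of > 200000 nM in this assay, at which 1 of the 3 values shown sits), so their true size remains open. A second chloro is therefore expected to lower the number slightly, perhaps by no more than the scatter. The expected step is a 1.8-fold lower number from compound 2 to compound 4 (0.25 log units; within the scatter). Compound 4 is estimated at 30000 nM, with an expected range of 10000 nM to 80000 nM.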

Compound 4, half-maximal inhibitory concentration: 3000 nM
Compound 4: the middle estimate sits 10-fold (1.00 log units) above what was measured; the whole stated range lies above it.
By their numbers in this assay, from the lowest: compound 4; then compounds 2 and 3 (each within the scatter of the next). At a limit, above all of these: compound 1.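

In this assay, chloro in place of hydrogen on an aromatic carbon, meta to a chloro group, gives an 18-fold lower number from compound 2 to compound 4 (1.25 log units; beyond the scatter), the only step shown that adds a group in place of hydrogen. Among the compounds shown here, the earlier steps only exchanged one group for another, and a 1.5-fold higher number from compound 2 to compound 3 (0.18 log units; within the scatter) stayed within the scatter, so this is the first step between two actual numbers that lies beyond it. Nothing given here accounts for the size of this step.

Going by these compounds, whether the same large step would follow from a methyl, a trifluoromethyl or an amine on this aromatic carbon remains open. Also open, on these data alone, is whether chloro in place of hydrogen on this carbon would lower the number for compound 3 as well, where cyano stands in place of the first chloro.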